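Replacing a Butyl Chain with a Cyclohexyl Ring

This account rests on a few compounds, and the source may have more. Where it says the series, first, only, none or still open, it means among the compounds named here.

Compound 1 `CCC/C(C)=N\Nc1nc(-c2cccc([N+](=O)[O-])c2)cs1` gives 55 nM in an assay on isolated protein for inhibition of Amine oxidase [flavin-containing] B (Homo sapiens), read by fluorescence, with a stated time of 20 min; on this read-out lower numbers stand for stronger inhibition and higher numbers for weaker inhibition.
Compound 2 `CCCC/C(C)=N\Nc1nc(-c2cccc([N+](=O)[O-])c2)cs1` gives 118 nM in this assay.

Among the measured compounds shown here, compound 2 stands at the higher, weaker, of the two numbers measured so far; the step from compound 1 to compound 2 is a 2.1-fold higher number from compound 1 to compound 2 (0.33 log units; beyond the scatter). Compound 3 `C/C(=N/Nc1nc(-c2cccc([N+](=O)[O-])c2)cs1)C1CCCCC1` differs from compound 2 by cyclohexyl in place of butyl on a carbon with a double bond to nitrogen. For the measured compounds named here, only one measured step bears on this change: extending the chain from compound 1 to compound 2 gave a 2.1-fold higher number from compound 1 to compound 2 (0.33 log units; beyond the scatter), a modest weakening. Going by the values given here, the change to compound 3 again adds carbon and also closes it into a six-membered ring, something no measured pair covers, so the expectation leans on that single step and stays uncertain. Compound 3 is expected to give 200 nM, within a range of 70 nM to 600 nM. The expected step of a 1.7-fold higher number from compound 2 to compound 3 (0.23 log units; within the scatter) would thus be a further modest weakening.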

Compound 3, half-maximal inhibitory concentration: 7.2 nM
Compound 3: middle estimate off by 28-fold (1.44 log units), on the high side, outside the stated range (below it).
By their numbers in this assay, from the lowest: compound 3; then compound 1; then compound 2.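

At this position, on a carbon with a double bond to nitrogen, the count of carbons alone does not set the result in this assay. Lengthening the open chain had raised the number, yet cyclohexyl in place of butyl brings a 16-fold lower number from compound 2 to compound 3 (1.21 log units; beyond the scatter) and so reverses that direction, with compound 3 going against the trend seen from compound 1 to compound 2. Cyclohexyl in place of propyl also brings a 7.6-fold lower number from compound 1 to compound 3 (0.88 log units; beyond the scatter) as a clear gain over the better of the two open chains, though no measurement available here explains why the ring does better.

The compounds shown leave open whether this gain belongs to the six-membered ring or to any carbon ring, which a cyclopentyl or cycloheptyl group would test. They also leave open whether a branched chain such as isopropyl, or a tetrahydropyranyl ring containing oxygen, would keep the low number.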